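The source may hold more compounds than are shown below. What is called first, only, known or untested is meant among the compounds shown, and "the series" means these compounds.

Compound 1 `O=C(O)CC[C@H](NC(=O)CN(c1nc(Cl)nc2[nH]cnc12)C1CC1)C(=O)O` and compound 2 `O=C(O)C[C@H](NC(=O)CN(c1nc(Cl)nc2[nH]cnc12)C1CC1)C(=O)O` share one core and differ only in the acid-bearing chain. In a functional assay on the whole organism (Tail, strain ICR) with Mus musculus as the target, in the tail flick test, with a stated time of 60 min, at a dose of 25 umol/kg by the oral route (a lower number here means a weaker effect, a higher number a stronger effect of the compound at the dose given), compound 1 gives 33.3%, and in this assay compound 2 gives 38.9%. For the measured compounds named here, of the two numbers, the one for compound 2 stands higher, yet the step of a number 5.6 percentage points higher from compound 1 to compound 2 (within the scatter) puts the pair within the scatter of each other, so no order between them is claimed. Compound 3 `NC(=O)CC[C@H](NC(=O)CN(c1nc(Cl)nc2[nH]cnc12)C1CC1)C(=O)O` is the next member; its difference from compound 2 is carbamoylmethyl in place of carboxy on a saturated chain carbon, two bonds along the chain from an amide-type nitrogen and a carbonyl carbon. Going by the values given here, the only measured step, a number 5.6 percentage points higher from compound 1 to compound 2 (within the scatter), exchanges carboxy for carboxymethyl at the same chain carbon and therefore speaks only to the length of the acid arm, not to the exchange of carboxy for carbamoylmethyl; it gives no precedent for a move in either direction. With nothing more to rest on, the step of a number 0.9 percentage points lower from compound 2 to compound 3 (within the scatter) is expected to stay within the scatter, and the range is kept wide to reflect that. The estimate for compound 3 in this assay is 38%, with a range from 20% to 58%.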

Compound 3, a percentage reported as activity, at one dose (the size of the read-out at that dose, not a potency): 38.4%
Estimate against measurement, compound 3: 0.4 percentage points below; the measured number falls inside the stated range.
By their numbers in this assay, from the lowest: compounds 1, 3 and 2 (each within the scatter of the next).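

In this assay, the arm on this saturated chain carbon now has a second kind of variation: the earlier pair differed only in the length of the acid arm, whereas the step of a number 5.1 percentage points higher from compound 1 to compound 3 (within the scatter) exchanges hydroxy for amino on a carbonyl carbon at constant arm length. The step of a number 0.5 percentage points lower from compound 2 to compound 3 (within the scatter) pairs carbamoylmethyl with carboxy and likewise stays within the scatter, so all three compounds form one group at this dose, with neither the end group nor this exchange of arms separating them. No measurement bearing on the reason for this result is available.

As far as these compounds go, whether an amine, a longer chain such as 3-carboxypropyl, or a plain methyl on the same saturated chain carbon would give a step beyond the scatter remains open. From the compounds shown here alone, the numbers come from one dose and one time point, so it is also open whether compound 1, compound 2 and compound 3 would stay within the scatter of one another at other doses.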